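Swapping the aryl group on the sulfonamide sulfur

This account rests on a few compounds, and the source may have more. Where it says the series, first, only, none or still open, it means among the compounds named here.

Compound 1 `C=Cc1ccc(S(=O)(=O)Nc2ccc(-c3nc4ccccc4o3)cc2)cc1` in an assay on cells for inhibition of HSP60/HSP10 (Homo sapiens), with a stated time of 60 min (on this read-out higher numbers stand for weaker inhibition and lower numbers for stronger inhibition), gives only a limit of the assay, > 100000 nM.
Compound 2 `O=S(=O)(Nc1ccc(-c2nc3ccccc3o2)cc1)c1ccc(O)cc1` gives 78000 nM.
Compound 3 `COc1cccc(S(=O)(=O)Nc2ccc(-c3nc4ccccc4o3)cc2)c1` gives 80000 nM.

All three compounds share the same core and differ only in the aryl group attached to the sulfonyl sulfur. Compound 3 stands highest of the two real numbers, but its nearest neighbour is compound 2, and the step of a 1.0-fold higher number from compound 2 to compound 3 (0.01 log units; within the scatter) lies within the scatter, so the two cannot be told apart. The value of compound 1 is a limit, so it sits apart from the numbers.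

Compound 4 `Cc1ccccc1S(=O)(=O)Nc1ccc(-c2nc3ccccc3o2)cc1` has not yet been measured. It differs from compound 3 in one place: 2-methylphenyl in place of 3-methoxyphenyl on a sulfonyl sulfur. Within the data shown here, two measured steps touch the same position. The step of a 1.0-fold higher number from compound 2 to compound 3 (0.01 log units; within the scatter) changed the aryl group on the sulfonyl sulfur without moving the number beyond the scatter. The step of an at least 1.2-fold lower number from compound 1 to compound 3 (0.09 log units; that floor lies within the scatter) is bounded only by a limit, and its floor also lies within the scatter. No measured change at this position has so far moved the number clearly.

Compound 4 is therefore expected to give 80000 nM, with a range from 35000 nM to 180000 nM. This estimate amounts to a step of no change at the digits printed from compound 3 to compound 4 (within the scatter), expected to stay within the scatter.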

Compound 4, half-maximal inhibitory concentration: 85000 nM
Beside the measured number, compound 4's estimate is 1.1-fold (0.03 log units) below it; the range from low to high includes it.
By their numbers in this assay, from the lowest: compounds 2, 3 and 4 (each within the scatter of the next). At a limit, above all of these: compound 1.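

In this assay, replacing 3-methoxyphenyl with 2-methylphenyl on the sulfonyl sulfur removes the one hydrogen-bond acceptor counted in the group that leaves, yet the result is a 1.1-fold higher number from compound 3 to compound 4 (0.03 log units; within the scatter). Set against the 4-hydroxyphenyl group, the new group gives the same picture, with a 1.1-fold higher number from compound 2 to compound 4 (0.04 log units; within the scatter), so compounds 2, 3 and 4, with three different aryl groups at this position, now all lie within the scatter of one another. Set against the 4-vinylphenyl group, the new group gives only a floor, with an at least 1.1-fold lower number from compound 1 to compound 4 (0.07 log units; that floor lies within the scatter). Compound 1 stands at a limit of the assay: the limit of > 100000 nM in this assay, at which 1 of the 4 values shown sits.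

Going by these compounds, it remains open what an amine or a carboxylic acid on the aryl group would do to the number in this assay, and what a longer chain would do in place of the aryl group on the sulfonyl sulfur. All the compounds shown also keep the shared core unchanged, so the effect of a change there on this read-out remains unknown.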